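This account rests on a few compounds, and the source may have more. Where it says the series, first, only, none or still open, it means among the compounds named here.

Compound 1: `CCCCCNc1ncnc2c1ncn2[C@@H]1O[C@H](COS(N)(=O)=O)[C@@H](O)[C@H]1O`; in a functional assay on K562 cells (Homo sapiens) for antiproliferative activity, read by CellTiter-Glo, with a stated time of 72 h (a higher number here means that more compound is needed for the effect, a lower number that less compound is needed), compound 1 gives 181 nM.
Compound 2: `CCCCCCNc1ncnc2c1ncn2[C@@H]1O[C@H](COS(N)(=O)=O)[C@@H](O)[C@H]1O`; compound 2 gives 160 nM.
Compound 3: `CCC(C)Nc1ncnc2c1ncn2[C@@H]1O[C@H](COS(N)(=O)=O)[C@@H](O)[C@H]1O`; the value of compound 3 is a limit of the assay, > 1000 nM.

Compound 2 stands lowest of the two numbers given, with compound 1 close to it: a 1.1-fold lower number from compound 1 to compound 2 (0.05 log units; within the scatter). The sole other entry, for compound 3, is a limit, the one noted as the limit of > 1000 nM in this assay, at which 1 of the 3 values shown sits.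

Compound 4, `CCCCCC(C)Nc1ncnc2c1ncn2[C@@H]1O[C@H](COS(N)(=O)=O)[C@@H](O)[C@H]1O`, is not yet measured. Its difference from compound 2: methyl in place of hydrogen on a saturated chain carbon bound to a nitrogen on an aromatic ring and a saturated chain carbon.

Among the compounds with values here, two measured steps bear on branching at the nitrogen: an at least 5.5-fold higher number from compound 1 to compound 3 (0.74 log units; beyond the scatter) and an at least 6.2-fold higher number from compound 2 to compound 3 (0.79 log units; beyond the scatter), both ending at the limit. Each of them pairs branching with a shorter chain. The data do not contain a step that changes branching alone. The step of a 1.1-fold lower number from compound 1 to compound 2 (0.05 log units; within the scatter) shows that adding a methyl further along the chain stays within the scatter. Compound 4 keeps the hexyl length and adds the methyl on the carbon bound to the nitrogen, so a higher number than compound 2 is expected, of modest size, with a real chance that only a limit is returned. The expected step is a 3.1-fold higher number from compound 2 to compound 4 (0.49 log units; beyond the scatter). Compound 4 is estimated at 500 nM, between 200 nM and 1500 nM.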

Compound 4, half-maximal effective concentration: 203 nM
Beside the measured number, compound 4's estimate is 2.5-fold (0.39 log units) above it; low and high end bracket the measured number.
By their numbers in this assay, from the lowest: compounds 2, 1 and 4 (each within the scatter of the next). At a limit, above all of these: compound 3.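

In this assay, within the data shown here, methyl in place of hydrogen on a saturated chain carbon bound to a nitrogen on an aromatic ring stays within the scatter, a 1.3-fold higher number from compound 2 to compound 4 (0.10 log units; within the scatter), and 1-methylhexyl in place of pentyl does the same, a 1.1-fold higher number from compound 1 to compound 4 (0.05 log units; within the scatter), so this branch on the hexyl chain alone is tolerated, which the earlier steps, each pairing branching with a shorter chain, could not show. The sec-butyl compound is set apart by the chain beyond the branch: propyl in place of hydrogen on a saturated chain carbon, three bonds along the chain from a nitrogen on an aromatic ring, gives an at least 4.9-fold lower number from compound 3 to compound 4 (0.69 log units; beyond the scatter). Compound 3 stands at a limit of the assay, so that step gives a bound and not a size: the limit of > 1000 nM in this assay, at which 1 of the 4 values shown sits.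

Open, on these data alone, is how much chain beyond the branch is needed, since a propyl or butyl group on this carbon would place the point at which the number rises, and whether a longer chain such as 1-methylheptyl, or a cyclohexyl ring on the nitrogen, is tolerated as well. Also open, as far as these compounds go, is whether a terminal amine or carboxylic acid on the chain fits this position.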